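Removing one methoxy from the core of compound 1

The source may hold more compounds than are shown below. What is called first, only, known or untested is meant among the compounds shown, and "the series" means these compounds.

In a functional assay on A549 cells (Homo sapiens) for antiproliferative activity, read by sulforhodamine B assay, with a stated time of 48 h (a higher number here means a weaker inhibitor, a lower number a stronger inhibitor), compound 1 (`COc1cc(C(=O)/C=C\Nc2ccc(-c3nc4cc(OC)c(OC)c(OC)c4s3)cc2C)cc([N+](=O)[O-])c1OC`) gives 17400 nM. Two relatives were measured alongside it. Compound 2 (`COc1ccc(C(=O)/C=C\Nc2ccc(-c3nc4cc(OC)c(OC)c(OC)c4s3)cc2C)cc1[N+](=O)[O-]`) gives 9100 nM, and compound 3 (`COc1ccc2nc(-c3ccc(N/C=C\C(=O)c4ccc(OC)c(O)c4)cc3)sc2c1`) gives 12800 nM. Both values lie within the scatter of compound 1, so compound 1 cannot be separated from either.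

Compound 4 (`COc1cc(OC)c2sc(-c3ccc(N/C=C\C(=O)c4cc(OC)c(OC)c([N+](=O)[O-])c4)c(C)c3)nc2c1`) departs from compound 1 at one place: hydrogen in place of methoxy on an aromatic carbon. In words, this is hydrogen in place of methoxy on an aromatic carbon.

Going by the values given here, the only measured exchange of this kind is a 1.9-fold lower number from compound 1 to compound 2 (0.28 log units; within the scatter), and it sits at a different place in the molecule. Among the compounds with values here, it is therefore a loose guide, and no measured step covers the exact position changed in compound 4. That step stayed within the scatter, so no shift beyond the scatter is expected in this assay. The estimated change is a 1.5-fold lower number from compound 1 to compound 4 (0.16 log units; within the scatter).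

For compound 4 the expected value is 12000 nM, with an estimated range of 5000 nM to 30000 nM.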

Compound 4, half-maximal inhibitory concentration: 15400 nM
Beside the measured number, compound 4's estimate is 1.3-fold (0.11 log units) below it, and the stated range covers the measured number.
By their numbers in this assay, from the lowest: compounds 2, 3, 4 and 1 (each within the scatter of the next).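

In this assay, the methoxy on the core, ortho to two methoxy groups, can be replaced by hydrogen with a 1.1-fold lower number from compound 1 to compound 4 (0.05 log units; within the scatter), so this position shows no change beyond the scatter. The earlier step, a 1.9-fold lower number from compound 1 to compound 2 (0.28 log units; within the scatter), concerned a methoxy at a different place, and the two exchanges now give the same reading at both places: neither step leaves the scatter. No measurement shown here accounts for this result.

The compounds shown leave open whether a group other than hydrogen at this position, such as an amine, a hydroxyl or a longer alkoxy chain, would move the number beyond the scatter. They also leave open whether replacing either of the two remaining methoxy groups on the core by hydrogen would do so.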